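Hydroxy in Place of Nitro: Expected Inhibition Shift

A few compounds are considered here, and "the series" means these few. Any claim that something is new, unique, unknown or untested is made for them only; others in the source may bear on it.

Compound 2 `Cn1cc(O)c(=O)cc1/C=C/c1ccc([N+](=O)[O-])cc1` gives 19200 nM in a functional assay, with a stated time of 10 min (on this read-out lower numbers stand for stronger inhibition and higher numbers for weaker inhibition), the highest of the two numbers seen so far, while compound 1 `Cn1cc(O)c(=O)cc1/C=C/c1ccccc1` gives 2110 nM. Compound 3 `Cn1cc(O)c(=O)cc1/C=C/c1ccc(O)cc1` differs from compound 2 by hydroxy in place of nitro on an aromatic carbon. Within the data shown here, the only measured step bearing on this is a 9.1-fold higher number from compound 1 to compound 2 (0.96 log units; beyond the scatter), so removing the nitro should move the number back toward that of compound 1, although hydroxy itself has no measured precedent here. The expected step is therefore a 7.7-fold lower number from compound 2 to compound 3 (0.89 log units; beyond the scatter). Compound 3 is estimated at 2500 nM, with a range from 800 nM to 8000 nM.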

Compound 3, half-maximal inhibitory concentration: 1370 nM
Compound 3: the middle estimate sits 1.8-fold (0.26 log units) above what was measured; measured number inside the range.
By their numbers in this assay, from the lowest: compounds 3 and 1 (each within the scatter of the next); then compound 2.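

Hydroxy in place of nitro gives a 14-fold lower number from compound 2 to compound 3 (1.15 log units; beyond the scatter) and so the weaker inhibition seen with nitro does not extend to every group on this aromatic carbon. Hydroxy in place of hydrogen gives a 1.5-fold lower number from compound 1 to compound 3 (0.19 log units; within the scatter) and so this position takes a hydroxy with no change beyond the usual scatter. No measurement here explains why nitro and hydroxy differ. Going by these compounds, whether an amine or a carboxylic acid at this position would track hydroxy or nitro stays open. So does whether methoxy would keep the number seen with hydroxy.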